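The source may hold more compounds than are shown below. What is called first, only, known or untested is meant among the compounds shown, and "the series" means these compounds.

- Compound 1 `C=CC(C)(O)CC[C@@H]1C(=C)CC[C@H](Br)[C@@]1(C)CCC(O)C(C)(C)O`: > 100000 nM (a limit, not a number)
- Compound 2 `C=CC(C)(O)CC[C@@H]1C(=C)CC[C@H](Br)[C@@]1(C)CCC1OC1(C)C`: 71700 nM

Within the data shown here, in a functional assay on MCF7 cells (Homo sapiens) for cytotoxicity, read by MTT assay, with a stated time of 48 h (a higher number here means a weaker inhibitor, a lower number a stronger inhibitor), compound 2 gives 71700 nM, the only actual number so far. Compound 1 is reported only as a limit, (the limit of > 100000 nM in this assay, at which 1 of the 2 values shown sits).

Compound 3 `C=CC(C)(O)CC[C@@H]1C(=C)CC[C@H](Br)[C@@]1(C)CCC(O)C(=C)C` has not been measured. It has 1-hydroxy-2-methylprop-2-en-1-yl in place of the 3,3-dimethyloxiran-2-yl of compound 2, on a saturated chain carbon, two bonds along the chain from a saturated ring carbon. The two have the same atoms, joined differently: 1-hydroxy-2-methylprop-2-en-1-yl in place of 3,3-dimethyloxiran-2-yl on a saturated chain carbon, two bonds along the chain from a saturated ring carbon.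

Among the measured compounds shown here, one measured step bears on this, because it changes the same place on the chain: an at least 1.3-fold lower number from compound 1 to compound 2 (0.14 log units; that floor lies within the scatter). There, 3,3-dimethyloxiran-2-yl replaces 1,2-dihydroxy-2-methylpropyl. As far as these compounds go, that step starts from a limit, so its true size is unknown, and it gives no direction for the new change. No step beyond the scatter is therefore expected in this assay.

The expected change is a 1.1-fold higher number from compound 2 to compound 3 (0.05 log units; within the scatter). The estimate for compound 3 is 80000 nM, with an expected range from 35000 nM to 160000 nM.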

Compound 3, half-maximal inhibitory concentration: > 100000 nM
Compound 3 ended at the assay's limit (the forecaster's own chance of this, stated with the estimate: 35%); at least 1.2-fold (0.09 log units) between middle value and limit.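

Compound 3 joins compound 1 at a limit rather than a number, which leaves compound 2, with its 3,3-dimethyloxiran-2-yl group, as the only one of the three with an actual value in this assay: the limit of > 100000 nM in this assay, at which 2 of the 3 values shown sit.

As far as these compounds go, exchanging that group for 1-hydroxy-2-methylprop-2-en-1-yl, which has the same atoms joined differently, gives an at least 1.3-fold higher number from compound 2 to compound 3 (0.14 log units; that floor lies within the scatter), so the true size of the step is unknown and its floor alone does not separate the two compounds. Both compounds without the three-membered ring at this place end at the limit, a weak hint from only these compounds that a readable value goes with that ring, while the step between compound 1 and compound 3 cannot be read, both values being limits.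

From the compounds shown here alone, no readable step here goes beyond the scatter, so it remains open whether the three-membered ring makes any real difference to the cell result. Going by these compounds, it is also open whether an amine, a carboxylic acid or a longer chain at this place on the shared core would give a clearly lower number than compound 2.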